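This account rests on a few compounds, and the source may have more. Where it says the series, first, only, none or still open, it means among the compounds named here.

In an assay on CHO cells for displacement of a labelled ligand from Substance-P receptor (Homo sapiens) (on this read-out lower numbers stand for stronger inhibition and higher numbers for weaker inhibition), compound 1, whose structure is `O=C(NCc1cc(C(F)(F)F)cc(C(F)(F)F)c1)C(c1ccccc1)c1ccccc1`, gives 526 nM. Compound 2, with the structure `CN(Cc1cc(C(F)(F)F)cc(C(F)(F)F)c1)C(=O)C(c1ccccc1)c1ccccc1`, differs from it only by methyl in place of hydrogen on an amide-type nitrogen, and in this assay compound 2 gives 47 nM. The measured step, an 11-fold lower number from compound 1 to compound 2 (1.05 log units; beyond the scatter), shows how much that one small change mattered. Compound 3, with the structure `O=C(CC(c1ccccc1)c1ccccc1)NCc1cc(Cl)cc(Cl)c1`, is built on a different core; the difference between the two cores is not broken down here. In this assay compound 3 gives 226 nM, which places it between compound 1 and compound 2. Compound 4, with the structure `CN(Cc1cc(Cl)cc(Cl)c1)C(=O)CC(c1ccccc1)c1ccccc1`, has not yet been measured. It relates to compound 3 by methyl in place of hydrogen on an amide-type nitrogen, the same change that turned compound 1 into compound 2, at a place described in identical words. Because the measured step is an 11-fold lower number from compound 1 to compound 2 (1.05 log units; beyond the scatter), a step in the same direction is expected here, though the changed core makes its size less certain, so the step expected for compound 4 is a 7.5-fold lower number from compound 3 to compound 4 (0.88 log units; beyond the scatter). On that basis compound 4 is estimated to give about 30 nM in this assay, most likely between 10 nM and 100 nM.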

Compound 4, half-maximal inhibitory concentration: 45 nM
Estimate against measurement, compound 4: 1.5-fold (0.18 log units) below; the measured number falls inside the stated range.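

In this assay, methyl in place of hydrogen on an amide-type nitrogen lowers the number on the second core as well (a 5.0-fold lower number from compound 3 to compound 4 (0.70 log units; beyond the scatter)), so the step seen on the core of compound 1 is repeated on the core of compound 3. Set side by side, the two steps run in the same direction and cannot be told apart in size: the same change on two cores in this assay, an 11-fold lower number (1.05 log units; beyond the scatter) from compound 1 to compound 2 and a 5.0-fold lower number (0.70 log units; beyond the scatter) from compound 3 to compound 4, 2.2-fold (0.35 log units) apart, within the scatter of two such steps. This supports carrying the change between these two cores only; two pairs of compounds give no general rule for other cores, and they do not show how the methyl produces its effect.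

The compounds shown leave open whether a longer chain, such as ethyl or propyl, on the same nitrogen would lower the number as methyl does. They also leave open whether the step would hold on a core carrying an amine or a carboxylic acid.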